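This account rests on a few compounds, and the source may have more. Where it says the series, first, only, none or still open, it means among the compounds named here.

- Compound 1 `O=C1COc2ccc(-c3cccc(NS(=O)(=O)c4ccc(F)cc4)c3)cc2N1`: > 40000 nM (a limit)
- Compound 2 `COc1ccc(N2C(=O)COc3ccc(-c4cnc(Cl)c(NS(=O)(=O)c5ccc(F)cc5)c4)cc32)cc1`: > 40000 nM (a limit)
- Compound 3 `COc1ncc(-c2ccc3c(c2)N(c2ccc(Cl)cc2)C(=O)CO3)cc1NS(=O)(=O)c1ccc(F)cc1`: 17900 nM

In a functional assay on HepG2 cells (Homo sapiens) for antiproliferative activity, read by MTT assay, with a stated time of 72 h (on this read-out lower numbers stand for stronger inhibition and higher numbers for weaker inhibition), compound 1 stands at > 40000 nM, which is a limit of the assay and not a number. It therefore marks only where the measurement stopped, and the set as a whole shows (the limit of > 40000 nM in this assay, at which 2 of the 3 values shown sit). Only compound 3 gives a true number, 17900 nM.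

Compound 4 `O=C1COc2ccc(-c3cccc(NS(=O)(=O)c4ccc(F)cc4)c3)cc2N1C1CCCCC1` is compound 1 with a single change: cyclohexyl in place of hydrogen on an amide-type nitrogen in a ring. Cyclohexyl takes the place of hydrogen on an amide-type nitrogen in a ring. For the measured compounds named here, no pair of measured compounds differs in one place, so no measured step can serve as a guide. Going by the values given here, with compound 3 at 17900 nM as the only true number, a small gain in this assay is expected, and no gain at all is quite possible. The expected change is an at least 1.3-fold lower number from compound 1 to compound 4 (0.12 log units; that floor lies within the scatter). For compound 4 the estimated value is 30000 nM, with an expected range from 12000 nM to 60000 nM.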

Compound 4, half-maximal inhibitory concentration: 35900 nM
Beside the measured number, compound 4's estimate is 1.2-fold (0.08 log units) below it; the measured number falls inside the stated range.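

On the core of compound 1, the amide-type nitrogen in the ring can carry cyclohexyl and still give a true number: in this assay, compound 4 gives 35900 nM. Compound 1 gives > 40000 nM, which is a limit of the assay and not a number. The change therefore reads only as an at least 1.1-fold lower number from compound 1 to compound 4 (0.04 log units; that floor lies within the scatter), a floor that lies within the scatter, so neither a real gain nor its size can be claimed, because the starting point is only a limit: the limit of > 40000 nM in this assay, at which 2 of the 4 values shown sit.

On these data alone, whether methyl, a longer chain ending in an amine, or a chain ending in a carboxylic acid on this same nitrogen would give a step beyond the scatter stays open. Also open, as far as these compounds go, is whether any group at this place could bring the core of compound 1 to a much lower number.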